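This account rests on a few compounds, and the source may have more. Where it says the series, first, only, none or still open, it means among the compounds named here.

The measured compounds so far:

Compound 1, `C=C(Br)C(=O)Nc1cccc(/C=C/C(=O)Nc2ccccc2)c1`: 5000 nM
Compound 2, `C=C(Br)C(=O)Nc1cccc(/C=C/C(=O)Nc2ccc(OC)cc2)c1`: 470 nM
Compound 3, `C=C(Br)C(=O)Nc1cccc(/C=C/C(=O)Nc2cc(OC)cc(OC)c2)c1`: 980 nM

All three share the same bromoacrylamide and cinnamanilide framework and were tested in a functional assay on Jurkat cells (Homo sapiens) for inhibition, read by MTT assay, with a stated time of 72 h; on this read-out lower numbers stand for stronger inhibition and higher numbers for weaker inhibition. In this assay, among the compounds with values here, compound 1 gives 5000 nM, and the single change to compound 2, (methoxy in place of hydrogen on an aromatic carbon), brings an 11-fold lower number from compound 1 to compound 2 (1.03 log units; beyond the scatter). Compound 3, which carries two methoxy groups on the terminal ring, gives 980 nM in this assay, a number somewhat higher than that of compound 2 and clearly lower than that of compound 1; the difference between the core of compound 1 and the core of compound 3 is not broken down here.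

Compound 4, `C=C(Br)C(=O)Nc1cccc(/C=C/C(=O)Nc2cc(OC)c(OC)c(OC)c2)c1`, has not yet been measured in this assay. It differs from compound 3 by methoxy in place of hydrogen on an aromatic carbon. Within the data shown here, this is the same kind of change as the one from compound 1 to compound 2, but not the same: in compound 4 the entering methoxy sits ortho to two methoxy groups and para to a large group, whereas in compound 2 the entering methoxy sits only para to a large group. Since compound 3 already carries two methoxy groups and gives 980 nM, the step to compound 4 is expected to be smaller than an 11-fold lower number from compound 1 to compound 2 (1.03 log units; beyond the scatter), estimated as a 2.0-fold lower number from compound 3 to compound 4 (0.29 log units; within the scatter). On this basis compound 4 is expected to give about 500 nM in this assay, with a likely range from 150 nM to 1600 nM.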

Compound 4, half-maximal inhibitory concentration: 290 nM
The estimate for compound 4 lay 1.7-fold (0.24 log units) above the measured number, and the stated range covers the measured number.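

In this assay, methoxy in place of hydrogen on an aromatic carbon again goes with a lower number, a 3.4-fold lower number from compound 3 to compound 4 (0.53 log units; beyond the scatter), and the direction of the change therefore carries over from the core of compound 1 to the core of compound 3. What does not carry over is the size of the step, and the earlier step cannot be applied unchanged to another core in this series: the same change on two cores in this assay, an 11-fold lower number (1.03 log units; beyond the scatter) from compound 1 to compound 2 and a 3.4-fold lower number (0.53 log units; beyond the scatter) from compound 3 to compound 4, 3.1-fold (0.50 log units) apart, beyond the scatter of two such steps

These two steps do not show why their sizes differ, nor do they establish a rule for any further core; the entering methoxy sits para to a large group in both cases, but in compound 4 it is also ortho to two methoxy groups, and the two steps start from different cores, and the pair cannot separate these differences.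

The compounds shown leave open how the terminal ring would respond to a larger alkoxy group such as ethoxy, or to a different group such as a hydroxyl, an amine or a carboxylic acid, in place of methoxy. They also leave open whether the same methoxy steps would hold if a plain acrylamide replaced the bromoacrylamide.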